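Swapping a fluorinated diol for a sulfonamide on the shared core

The source may report more compounds than this note shows. Statements on the series, on what has been measured and on what is new or still open speak of the compounds shown alone.

Of the compounds shown here, three sharing one core have been tested in an ADME assay (liver) for metabolic stability, with Liver microsome (Rattus norvegicus) as the target, using microsomes and NADPH, with a stated time of 30 min; a lower number here means slower removal, a higher number faster removal of the compound. Compound 1 `CC#C[C@H]1CN(S(=O)(=O)c2ccc(N)nc2)CCN1c1ccc(C(O)(COC)C(F)(F)F)cc1` gives 93 mL.min-1.g-1. Compound 2 `CC#C[C@H]1CN(S(=O)(=O)c2ccc(N)nc2)CCN1c1ccc(C(=O)NC)cc1` gives 41 mL.min-1.g-1. Compound 3 `CC#C[C@H]1CN(S(=O)(=O)c2ccc(N)nc2)CCN1c1ccc([C@@](O)(CO)C(F)(F)F)cc1` gives 53 mL.min-1.g-1. Among these three numbers compound 3 stands second highest; its nearest neighbour is compound 2, with a 1.3-fold higher number from compound 2 to compound 3 (0.11 log units; within the scatter), and the furthest is compound 1, with a 1.8-fold lower number from compound 1 to compound 3 (0.24 log units; within the scatter). Among the compounds with values here, only the step of a 2.3-fold lower number from compound 1 to compound 2 (0.36 log units; beyond the scatter) lies beyond the scatter, and even it is modest.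

Compound 4 `CC#C[C@H]1CN(S(=O)(=O)c2ccc(N)nc2)CCN1c1ccc(S(=O)(=O)NCC2CC2)cc1` differs from compound 3 in one place: a group of 8 heavy atoms (4 carbon, 1 nitrogen, 2 oxygen, 1 sulfur; one three-membered non-aromatic ring of carbon only) in place of a group of 8 heavy atoms (3 carbon, 2 oxygen, 3 fluorine; no ring), on an aromatic carbon. Within the data shown here, no measured step exchanges a fluorinated group for a sulfonamide, so the closest guide is the narrow band covered by compounds 1, 2 and 3, where very different groups on the same aromatic carbon gave numbers close together. A step of roughly a 1.1-fold higher number from compound 3 to compound 4 (0.05 log units; within the scatter) is therefore expected, which is no change beyond the scatter. Compound 4 is estimated to give 60 mL.min-1.g-1, within a range from 25 mL.min-1.g-1 to 150 mL.min-1.g-1.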

Compound 4, intrinsic clearance in microsomes: 213 mL.min-1.g-1
Compound 4: middle estimate off by 3.6-fold (0.55 log units), on the low side, and the stated range ends below it.
By their numbers in this assay, from the lowest: compounds 2, 3 and 1 (each within the scatter of the next, the first and the last beyond it); then compound 4.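

The earlier compounds shown here made this aromatic carbon look forgiving in this assay, but (cyclopropylmethyl)sulfamoyl leaves their narrow band, with a 4.0-fold higher number from compound 3 to compound 4 (0.60 log units; beyond the scatter) and a 5.2-fold higher number from compound 2 to compound 4 (0.72 log units; beyond the scatter) and also a 2.3-fold higher number from compound 1 to compound 4 (0.36 log units; beyond the scatter) as its steps. So the group at this place can shift the clearance well beyond the scatter, here towards faster removal, and compound 4 stands highest of the four. No measurement at hand bears on why the number rises.

Open, on these data alone, is which part of the new group carries the rise, the sulfonyl link or the cyclopropylmethyl end, as both enter together. A sulfamoyl group carrying only a methyl, or the amide of compound 2 carrying cyclopropylmethyl in place of its methyl, would pull those two parts apart.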